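Sulfonyl in place of carbonyl on the amine nitrogen

A few compounds are considered here, and "the series" means these few. Any claim that something is new, unique, unknown or untested is made for them only; others in the source may bear on it.

Measured so far, in an assay on a protein complex for inhibition of integrin alpha-5/beta-1 (Homo sapiens), read by ELISA; on this read-out lower numbers stand for stronger inhibition and higher numbers for weaker inhibition:
compound 1 `COc1ccnc(NC[C@@H]2C[C@@H](OCC(=O)NC[C@H](NS(=O)(=O)c3c(C)cc(C)cc3C)C(=O)O)CN2C(=O)OCc2ccccc2)c1` gives 1.1 nM
compound 2 `COc1ccnc(NC[C@@H]2C[C@@H](OCC(=O)NC[C@H](NC(=O)c3c(C)cc(C)cc3C)C(=O)O)CN2C(=O)CC(C)(C)C)c1` gives 0.55 nM

Compound 2 has the lowest of the two numbers in this assay, but its nearest neighbour, compound 1, sits within the usual scatter of it, so the two cannot be placed in any order; the pair shows only that both bind strongly. For the measured compounds named here, compound 1 and compound 2 differ in more than one place, so nothing about the single change below can be read from them directly.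

Compound 3 `COc1ccnc(NC[C@@H]2C[C@@H](OCC(=O)NC[C@H](NS(=O)(=O)c3c(C)cc(C)cc3C)C(=O)O)CN2C(=O)CC(C)(C)C)c1` is not yet measured. It differs from compound 2 in one place: (2,4,6-trimethylphenyl)sulfonyl in place of (2,4,6-trimethylphenyl)carbonyl on an amine nitrogen. The same sulfonyl group is already present in compound 1, which gives a number close to that of compound 2. On that basis no step beyond the scatter is expected from compound 2 to compound 3 in this assay, in either direction, which is what a 1.5-fold higher number from compound 2 to compound 3 (0.16 log units; within the scatter) expresses. Compound 3 is estimated to give 0.8 nM in this assay, with an expected range from 0.3 nM to 2.5 nM.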

Compound 3, half-maximal inhibitory concentration: 0.9 nM
Compound 3: the middle estimate sits 1.1-fold (0.05 log units) below what was measured; the measured number falls inside the stated range.
By their numbers in this assay, from the lowest: compounds 2, 3 and 1 (each within the scatter of the next).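

In this assay, the exchange of (2,4,6-trimethylphenyl)carbonyl for (2,4,6-trimethylphenyl)sulfonyl on the amine nitrogen can now be read directly as a 1.6-fold higher number from compound 2 to compound 3 (0.21 log units; within the scatter), so with neopentyl held constant this position accepts either group without a step beyond the scatter. With the sulfonyl held constant, neopentyl in place of benzyloxy on a carbonyl carbon gives a 1.2-fold lower number from compound 1 to compound 3 (0.09 log units; within the scatter), so the two changes that were mixed in the earlier pair now stand as separate steps, each within the scatter. Nothing at hand bears on the basis of either step.

Each change rests on a single pair, and both carry the 2,4,6-trimethylphenyl group. Going by these compounds, whether the sulfonyl and carbonyl remain interchangeable with an unsubstituted phenyl or a methyl on the same linker stays open.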